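The compounds below may be only part of what the source reports. "The series", "measured", "known", "first", "only" and "open" are said of these compounds alone.

Compound 3 `Cc1noc(-c2nc(C)c3c(c2N)C(=O)N(Cc2ccccc2F)C3=O)n1` stands at < 5000 nM in a physicochemical assay for solubility, using the shake flask method, in simulated intestinal fluid, measured as kinetic solubility, with a stated time of 2 h, at 25 degrees C, at pH 6.5 (on this read-out higher numbers stand for higher solubility and lower numbers for lower solubility), and that is a limit, not a number. Compound 1 `Cc1noc(-c2nc(C)c3c(c2N)C(=O)N(Cc2ccccc2)C3=O)n1` reads < 5000 nM and this too is a limit. Compound 3 and compound 1 thus share the limit of < 5000 nM in this assay, at which 2 of the 3 values shown sit, as their reading. Compound 2 `Cc1noc(-c2nc(C)c3c(c2N)C(=O)N(Cc2ccc(Oc4ccc(F)cc4)cc2)C3=O)n1` gives 23800 nM as a true number. Compound 4 `Cc1noc(-c2nc(C)c3c(c2N)C(=O)N(Cc2ccc(S(C)(=O)=O)cc2)C3=O)n1` follows from compound 3 through 4-(methylsulfonyl)phenyl in place of 2-fluorophenyl on a saturated chain carbon bound to an amide-type nitrogen in a ring and keeps the shared core. The step that the two limits leave unreadable from compound 1 to compound 3 gives no guide on size. Within the data shown here, the one readable step is an at least 4.7-fold higher number from compound 1 to compound 2 (0.67 log units; beyond the scatter) and it adds a group on an aromatic carbon, so a modest rise is expected in this assay for the new group too. The estimated step is an at least 1.4-fold higher number from compound 3 to compound 4 (0.14 log units; that floor lies within the scatter) and the reading may still end in a limit. For compound 4 the expected value is 7000 nM with an estimated range from 2500 nM to 30000 nM overall.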

Compound 4, solubility: < 5000 nM
Compound 4: a limit, no number; the forecaster's own chance of this, stated with the estimate: 45%; at least 1.4-fold (0.14 log units) between middle value and limit.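

In this assay, among these compounds, the reading of compound 4 is a limit, the one already shared by compound 1 and compound 3: the limit of < 5000 nM in this assay, at which 3 of the 4 values shown sit. Methylsulfonyl in place of 4-fluorophenoxy on an aromatic carbon gives an at least 4.7-fold lower number from compound 2 to compound 4 (0.67 log units; beyond the scatter), so among the groups shown on this aromatic carbon, only 4-fluorophenoxy gives a true number, with methylsulfonyl going against any general gain from adding a group. The steps from compound 1 and from compound 3 to compound 4 cannot be read.

Going by these compounds, how far compound 1, compound 3 and compound 4 differ beneath their shared limit stays open. So does whether an amine, a carboxylic acid or a longer alkoxy chain on this aromatic carbon would give a true number.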